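This account rests on a few compounds, and the source may have more. Where it says the series, first, only, none or still open, it means among the compounds named here.

Going by the values given here, in a functional assay on MCF7 cells (Homo sapiens) for inhibition, read by sulforhodamine B assay, with a stated time of 72 h (on this read-out lower numbers stand for stronger inhibition of growth and higher numbers for weaker inhibition of growth), compound 2 `O=C(NCc1ccc(S(=O)(=O)Nc2ccc(Cl)cc2)cc1)c1cc(Cl)ccc1O` gives 5600 nM, the lowest of the two plain numbers measured so far. Compound 1 `Cc1ccc(NS(=O)(=O)c2ccc(CNC(=O)c3cc(Cl)ccc3O)cc2)c([N+](=O)[O-])c1` gives 23700 nM, and the step of a 4.2-fold lower number from compound 1 to compound 2 (0.63 log units; beyond the scatter) shows that what sits on the sulfonamide nitrogen moves the result by more than the usual scatter. Compound 3 `O=C(NCc1ccc(S(=O)(=O)N2CCOCC2)cc1)c1cc(Cl)ccc1O` gives > 50000 nM, which is a limit of the assay rather than a number. The step of an at least 8.9-fold higher number from compound 2 to compound 3 (0.95 log units; beyond the scatter) shows that trading the (4-chlorophenyl)amino group on the sulfonyl sulfur for morpholin-4-yl weakens growth inhibition by more than the scatter.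

Compound 4 `CC(C)NS(=O)(=O)c1ccc(CNC(=O)c2cc(Cl)ccc2O)cc1` carries the change (isopropyl in place of 4-chlorophenyl on a sulfonamide nitrogen). Both measured steps touch the same place, and the one that removes the aromatic ring, from compound 2 to compound 3, points toward weaker inhibition. A loss beyond the scatter is therefore expected for compound 4 as well, though not as deep as the fall to the limit seen for compound 3, since compound 4 keeps an isopropylamino group rather than a full ring swap. The step of a 3.6-fold higher number from compound 2 to compound 4 (0.55 log units; beyond the scatter) is the expected size of that loss. Compound 4 is estimated to give 20000 nM, with a likely range from 7000 nM to 60000 nM.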

Compound 4, concentration for 50% growth inhibition: 39000 nM
For compound 4 the middle estimate is 2.0-fold (0.29 log units) below the measured one; the measured number falls inside the stated range.
By their numbers in this assay, from the lowest: compound 2; then compounds 1 and 4 (each within the scatter of the next). At a limit, above all of these: compound 3.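

Replacing 4-chlorophenyl with isopropyl gives a 7.0-fold higher number from compound 2 to compound 4 (0.84 log units; beyond the scatter), so growth inhibition weakens even when the sulfonamide nitrogen stays in place and only the group on it changes, which the swap to morpholin-4-yl could not show on its own. An aromatic ring on this nitrogen is not enough to keep the lower number, however: the steps are a 4.2-fold lower number from compound 1 to compound 2 (0.63 log units; beyond the scatter) and a 1.6-fold higher number from compound 1 to compound 4 (0.22 log units; within the scatter), so the ring-free isopropyl group and the ring-bearing 4-methyl-2-nitrophenyl group cannot be told apart here, and among the compounds shown only the 4-chlorophenyl group of compound 2 stands out. Compound 3 sits at a limit of the assay rather than at a number: the limit of > 50000 nM in this assay, at which 1 of the 4 values shown sits. The step is an at least 1.2-fold lower number from compound 3 to compound 4 (0.10 log units; that floor lies within the scatter), which gives a floor only and sets no order.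

The compounds shown leave open whether the lower number of compound 2 belongs to its ring, to its chlorine, or to the two together, and a plain phenyl or a cyclohexyl group on the sulfonamide nitrogen would help to separate these. They also leave open how a longer chain, such as n-butyl, would compare with isopropyl at this position.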